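This account rests on a few compounds, and the source may have more. Where it says the series, first, only, none or still open, it means among the compounds named here.

Going by the values given here, compound 2 `Cc1ccsc1C(=CCCN(C)C(CCO)C(=O)NCc1ccccc1)c1sccc1C` stands highest of the two numbers so far in a physicochemical assay for lipophilicity, read by HPLC (a higher number here means a more lipophilic compound, a lower number a more polar compound), where compound 2 gives 5.71; compound 1 `Cc1ccsc1C(=CCCN(C)C(CCN)C(=O)NCc1ccccc1)c1sccc1C` gives 5.5, and the step of a number 0.21 log units higher from compound 1 to compound 2 (within the scatter). Compound 3 `Cc1ccsc1C(=CCCN(C)C(CCO)C(=O)NCc1ccccc1Cl)c1sccc1C` differs from compound 2 by chloro in place of hydrogen on an aromatic carbon. Among the compounds with values here, no measured step touches the benzyl group: the only step in hand concerns the chain and lies within the scatter, so it gives no guide here. The entering chloro adds one heavy atom and no donor or acceptor; on that basis compound 3 is expected to give a higher number in this assay, a number 0.59 log units higher from compound 2 to compound 3 (beyond the scatter). Compound 3 is estimated at 6.3, with a range from 5.9 to 6.7.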

Compound 3, partition coefficient: 6.23
For compound 3 the middle estimate is 0.07 log units above the measured one; the range from low to high includes it.
By their numbers in this assay, from the lowest: compounds 1 and 2 (each within the scatter of the next); then compound 3.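

Chloro in place of hydrogen on an aromatic carbon, ortho to a large group, gives a number 0.52 log units higher from compound 2 to compound 3 (beyond the scatter) in this assay. Going by these compounds alone, the earlier step on the chain stayed within the scatter, so the benzyl ring is the first place where one change clearly separates two compounds. Nothing measured here accounts for the size of this step. Still open, going by these compounds, is whether the step holds with chloro on other carbons of that ring, or with fluoro or methoxy in its place. On these data alone, it is also open whether it carries over to the amino chain of compound 1.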